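The compounds below may be only part of what the source reports. "The series", "measured", "known", "first", "only" and "open" are said of these compounds alone.

Measured in a functional assay on HT-29 cells (Homo sapiens) for inhibition, read by MTT assay, with a stated time of 3 days; on this read-out higher numbers stand for weaker inhibition and lower numbers for stronger inhibition:
- compound 1 `COc1ccccc1/C=C/CCCOc1cc(/C=C\c2cc(OC)c(OC)c(OC)c2)ccc1OC`: 86000 nM
- compound 2 `COc1cccc(/C=C/CCCOc2cc(/C=C\c3cc(OC)c(OC)c(OC)c3)ccc2OC)c1`: 25000 nM
- compound 3 `COc1ccc(/C=C/CCCOc2cc(/C=C\c3cc(OC)c(OC)c(OC)c3)ccc2OC)cc1`: 47000 nM

These three compounds differ only in where the methoxy group sits on the phenyl ring at the end of the chain. Compound 3, at 47000 nM, cannot be separated from either of the other two: the data show a 1.8-fold lower number from compound 1 to compound 3 (0.26 log units; within the scatter) and a 1.9-fold higher number from compound 2 to compound 3 (0.27 log units; within the scatter). Going by the values given here, the only step beyond the scatter is a 3.4-fold lower number from compound 1 to compound 2 (0.54 log units; beyond the scatter), and it is modest.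

The next compound is compound 4 `COCOc1ccccc1/C=C/CCCOc1cc(/C=C\c2cc(OC)c(OC)c(OC)c2)ccc1OC`, which changes one group of compound 3: 2-(methoxymethoxy)phenyl in place of 4-methoxyphenyl on a double-bonded chain carbon bound to a double-bonded chain carbon. Among the compounds with values here, the group is a 2-(methoxymethoxy)phenyl in place of 4-methoxyphenyl, and no measured compound carries it. The nearest guide is compound 1, whose name also places its group at position 2 of the phenyl ring, and its value of 86000 nM sits within the scatter of compound 3. The steps seen so far are small, so only a small move is expected, with no clear change beyond the scatter. The expected step is a 1.3-fold higher number from compound 3 to compound 4 (0.11 log units; within the scatter). For compound 4 the estimate is 60000 nM, with an expected range of 22000 nM to 150000 nM.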

Compound 4, half-maximal inhibitory concentration: 9600 nM
For compound 4 the middle estimate is 6.3-fold (0.80 log units) above the measured one; the whole stated range lies above it.
By their numbers in this assay, from the lowest: compound 4; then compounds 2, 3 and 1 (each within the scatter of the next, the first and the last beyond it).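

Replacing the 2-methoxyphenyl group of compound 1 with the 2-(methoxymethoxy)phenyl group gives a 9.0-fold lower number from compound 1 to compound 4 (0.95 log units; beyond the scatter), the largest step among these compounds in this assay. Going by these compounds alone, the same group also stands clear of the other two end groups, with a 2.6-fold lower number from compound 2 to compound 4 (0.42 log units; beyond the scatter) and a 4.9-fold lower number from compound 3 to compound 4 (0.69 log units; beyond the scatter), which makes compound 4 the strongest inhibitor here and the only compound separated from all three others. The earlier compounds shown here varied only where a methoxy group sat on the phenyl ring and gave small steps, whereas this result shows that what is attached to the ring can matter more, since the two compounds that bear a 2-substituted ring lie furthest apart.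

Nothing measured here explains why the methoxymethoxy group goes with the lower number. Going by these compounds, it also remains open whether a 2-hydroxyphenyl or 2-ethoxyphenyl group would behave the same way, and whether a 3-(methoxymethoxy)phenyl or 4-(methoxymethoxy)phenyl group would keep the gain.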